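A few compounds are considered here, and "the series" means these few. Any claim that something is new, unique, unknown or untested is made for them only; others in the source may bear on it.

Measured so far in a functional assay on A549 cells (Homo sapiens) for antiproliferative activity, read by CCK-8 assay, with a stated time of 48 h; a lower number here means a stronger inhibitor, a higher number a weaker inhibitor:
- compound 1 `O=c1c2ccccc2[se]n1-c1nc(SCc2ccccc2)n[nH]1` — > 50000 nM (a limit)
- compound 2 `Cc1cccc(CSc2n[nH]c(-n3[se]c4ccccc4c3=O)n2)c1` — 12400 nM

In this assay compound 1 gives > 50000 nM, which is a limit of the assay and not a number. Compound 2 gives 12400 nM in this assay. Going by the values given here, the only measured step, an at least 4.0-fold lower number from compound 1 to compound 2 (0.60 log units; beyond the scatter), is open-ended because compound 1 sits at the limit of > 50000 nM in this assay, at which 1 of the 2 values shown sits; compound 1 is thus known only by that limit and stands at the weak end of the two values shown.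

Compound 3 `CCCCCSc1n[nH]c(-n2[se]c3ccccc3c2=O)n1` differs from compound 1 by butyl in place of phenyl on a saturated chain carbon bound to a sulfur. Among the compounds with values here, no measured step covers a ring-to-chain exchange at this position; the step from compound 1 to compound 2 concerns a methyl on the aromatic ring and does not transfer directly. The account therefore expects compound 3 to remain a weak inhibitor, with a step of an at least 1.6-fold lower number from compound 1 to compound 3 (0.22 log units; that floor lies within the scatter) that could fall within the scatter. Compound 3 is estimated at 30000 nM, within 8000 nM to 100000 nM.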

Compound 3, half-maximal inhibitory concentration: 21100 nM
Compound 3: the middle estimate sits 1.4-fold (0.15 log units) above what was measured; low and high end bracket the measured number.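

Putting butyl in place of phenyl on the saturated chain carbon bound to a sulfur gives an at least 2.3-fold lower number from compound 1 to compound 3 (0.37 log units; beyond the scatter), so in this assay this position accepts a chain with no aromatic ring and still gives a measurable value. From the compounds shown here alone, the size of that step stays open-ended since compound 1 is known only by a limit: the limit of > 50000 nM in this assay, at which 1 of the 3 values shown sits. Replacing the 3-methylphenyl group with butyl gives a 1.7-fold higher number from compound 2 to compound 3 (0.23 log units; within the scatter), so the assay does not tell these two groups apart.

The compounds shown leave open how a longer chain, or an amine or a carboxylic acid carried on the chain, would read in this assay. They also leave open whether a chlorine or a methoxy group on the phenyl ring would act as the methyl does.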